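Lengthening the hexyloxy chain: compound 3 to compound 4

The compounds below may be only part of what the source reports. "The series", "measured", "known", "first", "only" and "open" are said of these compounds alone.

In a functional assay on brain (Rattus norvegicus, strain Wistar) for inhibition (a higher number here means a weaker inhibitor, a lower number a stronger inhibitor), compound 1 `CCCCc1ccc(-c2c(C)[nH]c(=O)n2C2CCCCC2)cc1` gives 27100 nM, compound 2 `Cc1[nH]c(=O)n(C2CCCCC2)c1-c1ccc(OC(C)C)cc1` gives 13000 nM and compound 3 `CCCCCCOc1ccc(-c2c(C)[nH]c(=O)n2C2CCCCC2)cc1` gives 8500 nM. Two steps place compound 3: a 3.2-fold lower number from compound 1 to compound 3 (0.50 log units; beyond the scatter) lies beyond the scatter, while a 1.5-fold lower number from compound 2 to compound 3 (0.18 log units; within the scatter) lies within it. Compound 3 therefore stands clearly apart only from compound 1.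

The next structure, compound 4 `CCCCCCCCCCCCCCCCCCOc1ccc(-c2c(C)[nH]c(=O)n2C2CCCCC2)cc1`, carries dodecyl in place of hydrogen on a saturated chain carbon, six bonds along the chain from an oxygen on an aromatic ring.

The evidence for this change is thin. For the measured compounds named here, only one measured step alters the group on the oxygen, and it stays within the scatter. The modest steps of a 2.1-fold lower number from compound 1 to compound 2 (0.32 log units; beyond the scatter) and a 3.2-fold lower number from compound 1 to compound 3 (0.50 log units; beyond the scatter) replace butyl on an aromatic carbon, so they bear only indirectly. Going by the values given here, no measured compound has a chain approaching this length, which leaves either direction open. Resting on a 1.5-fold lower number from compound 2 to compound 3 (0.18 log units; within the scatter), no step beyond the scatter is expected in this assay. The estimated step is a 1.2-fold lower number from compound 3 to compound 4 (0.08 log units; within the scatter), which is expected to stay within the scatter. For compound 4 the estimated value is 7000 nM, with an expected range of 2000 nM to 30000 nM.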

Compound 4, half-maximal inhibitory concentration: > 100000 nM
Compound 4 was reported as a limit; the forecaster's own chance of this, stated with the estimate: 15%; at least 14-fold (1.15 log units) between middle value and limit.
By their numbers in this assay, from the lowest: compounds 3 and 2 (each within the scatter of the next); then compound 1. At a limit, above all of these: compound 4.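

In this assay compound 4 gives > 100000 nM, which is a limit of the assay and not a number. Dodecyl in place of hydrogen on a saturated chain carbon, six bonds along the chain from an oxygen on an aromatic ring, gives an at least 11-fold higher number from compound 3 to compound 4 (1.07 log units; beyond the scatter), the first change to the group on the oxygen that goes beyond the scatter, whereas a 1.5-fold lower number from compound 2 to compound 3 (0.18 log units; within the scatter) stays within it, so this position of the chain does not accept any length without loss in this assay. The reading of compound 4 rests on a single result at the top of the range, so it fixes a direction and no exact size for the step: the limit of > 100000 nM in this assay, at which 1 of the 4 values shown sits.

The compounds shown hold nothing between the hexyloxy chain of compound 3 and the far longer chain of compound 4, so the length at which the number begins to rise remains open, for example with an octyl or decyl group on the oxygen. Also open, going by these compounds, is whether a long chain ending in a carboxylic acid or an amine would behave as the plain chain of compound 4 does.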